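From a small chloro to a larger phenoxy group

A few compounds are considered here, and "the series" means these few. Any claim that something is new, unique, unknown or untested is made for them only; others in the source may bear on it.

Compound 1 `Cc1cccc(NS(=O)(=O)c2ccc(N3CCNC3=O)cc2)c1` (190 nM), compound 2 `O=C1NCCN1c1ccc(S(=O)(=O)Nc2cccc(Br)c2)cc1` (100 nM) and compound 3 `O=C1NCCN1c1ccc(S(=O)(=O)Nc2cccc(Cl)c2)cc1` (79 nM) share one core and have been measured in a functional assay on MCF7 cells (Homo sapiens) for antiproliferative activity, read by sulforhodamine B assay, with a stated time of 48 h (a higher number here means a weaker inhibitor, a lower number a stronger inhibitor), so far. Compound 3 sits at the low end of these numbers together with compound 2. The two cannot be told apart, as the step is a 1.3-fold lower number from compound 2 to compound 3 (0.10 log units; within the scatter) and does not separate them. Among the compounds with values here, compound 1 stands clearly apart from compound 3 only, with a 2.4-fold lower number from compound 1 to compound 3 (0.38 log units; beyond the scatter) as the one step that counts, whereas a 1.9-fold lower number from compound 1 to compound 2 (0.28 log units; within the scatter) does not.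

Compound 4 `O=C1NCCN1c1ccc(S(=O)(=O)Nc2cccc(Oc3ccccc3)c2)cc1` carries phenoxy in place of chloro on an aromatic carbon and otherwise matches compound 3. The measured steps only trade methyl, bromo and chloro, and none brings in a ring, so they are a weak guide to a group this large. Even the largest of them, a 2.4-fold lower number from compound 1 to compound 3 (0.38 log units; beyond the scatter) in size, is modest. Within the data shown here, no measured compound carries a comparable group, so the direction is a cautious expectation: a move to a higher number, meaning a weaker inhibitor, in this assay and somewhat larger than those steps. The estimated step is a 3.2-fold higher number from compound 3 to compound 4 (0.50 log units; beyond the scatter) and it carries wide uncertainty. Compound 4 is estimated at 250 nM with an expected range (50 nM to 1200 nM).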

Compound 4, half-maximal inhibitory concentration: 220 nM
For compound 4 the middle estimate is 1.1-fold (0.06 log units) above the measured one; the range from low to high includes it.
By their numbers in this assay, from the lowest: compounds 3, 2, 1 and 4 (each within the scatter of the next, the first and the last beyond it).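

The earlier compounds shown here only traded small groups at this position, an aromatic carbon of a six-membered aromatic ring of carbon only, and compound 4 shows that a group bearing a whole extra ring still leaves clear activity in this assay: swapping chloro for phenoxy gives a 2.8-fold higher number from compound 3 to compound 4 (0.44 log units; beyond the scatter) and swapping bromo for phenoxy gives a 2.2-fold higher number from compound 2 to compound 4 (0.34 log units; beyond the scatter), both modest losses for a group of 7 heavy atoms. Methyl tells a different story, since a 1.2-fold higher number from compound 1 to compound 4 (0.06 log units; within the scatter) does not separate the two compounds, so compound 1, with its small methyl, goes against any simple rule that a larger group here means a weaker inhibitor. No measurement at hand explains why the numbers fall in this order.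

The compounds shown do not tell whether the change comes from the added ring or from the oxygen that links it, a question that a methoxy group or a directly attached phenyl at the same place could help to answer. On these data alone, how an amine or a carboxylic acid would behave here, or on the added ring, also remains open.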